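From 4-iodophenyl to 3-methoxyphenyl on the sulfonamide nitrogen

This account rests on a few compounds, and the source may have more. Where it says the series, first, only, none or still open, it means among the compounds named here.

Compound 1 `O=C1NCCN1c1ccc(S(=O)(=O)Nc2ccc(I)cc2)cc1` gives 260 nM in a functional assay on M21 cells (Homo sapiens) for antiproliferative activity, read by sulforhodamine B assay, with a stated time of 48 h (a lower number here means a stronger inhibitor, a higher number a weaker inhibitor), the lowest of the two numbers in hand. Compound 2 `O=C1NCCN1c1ccc(S(=O)(=O)Nc2ccc(OC(F)F)cc2)cc1` gives 410 nM in this assay, and the step of a 1.6-fold higher number from compound 1 to compound 2 (0.20 log units; within the scatter) lies within the scatter. Compound 3 `COc1cccc(NS(=O)(=O)c2ccc(N3CCNC3=O)cc2)c1` differs from compound 1 by 3-methoxyphenyl in place of 4-iodophenyl on a sulfonamide nitrogen. Among the compounds with values here, the only measured step, which also exchanged the iodo group on that ring, was small; no step covers a 3-methoxyphenyl, so the expectation rests on that single precedent. Compound 3 is therefore expected to give roughly 600 nM in this assay, between 250 nM and 1500 nM, a step of a 2.3-fold higher number from compound 1 to compound 3 (0.36 log units; beyond the scatter).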

Compound 3, half-maximal inhibitory concentration: 65 nM
Estimate against measurement, compound 3: 9.2-fold (0.97 log units) above; the measured number lies below the stated range.
By their numbers in this assay, from the lowest: compound 3; then compounds 1 and 2 (each within the scatter of the next).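

In this assay, 3-methoxyphenyl in place of 4-iodophenyl on a sulfonamide nitrogen gives a 4.0-fold lower number from compound 1 to compound 3 (0.60 log units; beyond the scatter) and is the only step shown that lies beyond the scatter. This position therefore responds to a change of its aryl group, which the earlier pair, whose step stayed within the scatter, did not show. No evidence given here accounts for this difference.

The compounds shown do not separate the effect of the methoxy group from that of its ring position. They also leave open how an ethoxy group, an amine or a carboxylic acid on that ring would fare.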